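This account rests on a few compounds, and the source may have more. Where it says the series, first, only, none or still open, it means among the compounds named here.

In a functional assay on HeLa cells (Homo sapiens) for antiproliferative activity, read by MTT assay, with a stated time of 48 h (a higher number here means a weaker inhibitor, a lower number a stronger inhibitor), the measured compounds read as follows:
compound 1 (`O=[N+]([O-])c1cccc(-c2nn(-c3ccccc3)cc2C(Nc2nc3ccccc3s2)c2c(O)ccc3ccccc23)c1`) gives 8220 nM
compound 2 (`COc1cccc(-c2nn(-c3ccccc3)cc2C(Nc2nc3ccccc3s2)c2c(O)ccc3ccccc23)c1`) gives 14900 nM
compound 3 (`COc1ccc(-c2nn(-c3ccccc3)cc2C(Nc2nc3ccccc3s2)c2c(O)ccc3ccccc23)cc1`) gives 9340 nM

Compound 2 at 14900 nM lies within the scatter of both others, with a 1.8-fold higher number from compound 1 to compound 2 (0.26 log units; within the scatter) and a 1.6-fold lower number from compound 2 to compound 3 (0.20 log units; within the scatter) as the steps. Compound 4 (`COc1cccc(-c2nn(-c3ccccc3)cc2C(Nc2nc3ccc(Cl)cc3s2)c2c(O)ccc3ccccc23)c1`) differs from compound 2 by chloro in place of hydrogen on an aromatic carbon, which turns 1,3-benzothiazol-2-yl into 6-chloro-1,3-benzothiazol-2-yl. Among the measured compounds shown here, no measured step touches that group: a 1.1-fold higher number from compound 1 to compound 3 (0.06 log units; within the scatter) and the two steps above only exchange 3-nitrophenyl, 3-methoxyphenyl and 4-methoxyphenyl, all within the scatter. No step beyond the scatter is therefore expected in this assay for this change. The estimated change is a 1.4-fold lower number from compound 2 to compound 4 (0.13 log units; within the scatter) and stays within the scatter. Compound 4 is expected at 11000 nM with an estimated range from 5000 nM to 25000 nM overall.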

Compound 4, half-maximal inhibitory concentration: 30000 nM
The estimate for compound 4 lay 2.7-fold (0.44 log units) below the measured number; the measured number lies above the stated range.
By their numbers in this assay, from the lowest: compounds 1, 3, 2 and 4 (each within the scatter of the next, the first and the last beyond it).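

Compound 4 carries the first change shown on the 1,3-benzothiazol-2-yl group, since the earlier steps exchanged only the substituted phenyl groups. In this assay, chloro in place of hydrogen gives a 2.0-fold higher number from compound 2 to compound 4 (0.30 log units; within the scatter), so this single change at this place cannot be told apart from the scatter. Nothing available here bears on this result.

The compounds shown leave open whether an amine or a carboxylic acid on the same ring would also stay within the scatter. They also leave open whether chloro would give a similar step alongside 3-nitrophenyl or 4-methoxyphenyl.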